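The source may report more compounds than this note shows. Statements on the series, on what has been measured and on what is new or still open speak of the compounds shown alone.

Measured in a functional assay on KMS-11 cells (Homo sapiens) for antiproliferative activity, read by CellTiter-Glo, with a stated time of 72 h; a lower number here means a stronger inhibitor, a higher number a weaker inhibitor:
- compound 1 `COc1ccc(C(=O)N(Cc2ccncc2)Cc2cccc(OCCc3ccc(C)cc3)c2)cc1`: 9100 nM
- compound 2 `COc1ccc(C(=O)N(Cc2ccncc2)Cc2cccc(OCc3ccc(F)cc3)c2)cc1`: 22700 nM

Compound 2 holds the higher of the two numbers, at 22700 nM. Compound 3 `COc1ccc(C(=O)N(Cc2ccncc2)Cc2cccc(OCc3cccc(OC)c3)c2)cc1` carries 3-methoxyphenyl in place of 4-fluorophenyl on a saturated chain carbon bound to an oxygen on an aromatic ring. Within the data shown here, one measured step bears on this, at the same place: a 2.5-fold higher number from compound 1 to compound 2 (0.40 log units; beyond the scatter). Among the measured compounds shown here, no measured compound carries 3-methoxyphenyl, so the direction is open, and a step no larger than that modest one is expected in this assay, probably none beyond the scatter. The expected step is a 1.3-fold lower number from compound 2 to compound 3 (0.10 log units; within the scatter). Compound 3 is estimated at 18000 nM, with an expected range of 8000 nM to 40000 nM.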

Compound 3, half-maximal inhibitory concentration: 16900 nM
For compound 3 the middle estimate is 1.1-fold (0.03 log units) above the measured one; low and high end bracket the measured number.
By their numbers in this assay, from the lowest: compounds 1, 3 and 2 (each within the scatter of the next, the first and the last beyond it).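

In this assay, 3-methoxyphenyl in place of 4-fluorophenyl gives a 1.3-fold lower number from compound 2 to compound 3 (0.13 log units; within the scatter) and so does not separate the two compounds, although a methoxy oxygen and a hydrogen-bond acceptor enter at this place. Against 4-methylbenzyl, 3-methoxyphenyl shows a 1.9-fold higher number from compound 1 to compound 3 (0.27 log units; within the scatter) and so does not repeat the step beyond the scatter seen with 4-fluorophenyl. No supporting data explain these numbers.

Still open, as far as these compounds go, is whether an amine or a carboxylic acid on this chain carbon, or a longer chain than in compound 1, would move the number beyond the scatter.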